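Chloro to Hydrogen: One Step Estimated

The compounds below may be only part of what the source reports. "The series", "measured", "known", "first", "only" and "open" are said of these compounds alone.

Measured compounds:
compound 1 `CNC(=O)c1cc(C(=O)N[C@H]2CC[C@H](O)CC2)c([C@@H](C)c2cccc(Cl)c2)o1` gives 0.9 L/kg in an ADME assay on the whole organism (Canis lupus familiaris, strain Beagle) for pharmacokinetics, read by LC-MS, with a stated time of 7 h; a lower number here means that more of the compound stays in the plasma, a higher number that more of the compound sits outside the plasma
compound 2 `CNC(=O)c1cc(C(=O)N[C@H]2CC[C@H](O)CC2)n([C@@H](C)c2ccccc2)n1` gives 0.9 L/kg in this assay

Compound 1 stands level with compound 2 at the digits reported, and the two values lie within the scatter of one another, so nothing separates them. Among the measured compounds shown here, no pair of measured compounds differing in a single place is available, so the change toward compound 3 has to be judged on its own. Compound 3 `CNC(=O)c1cc(C(=O)N[C@H]2CC[C@H](O)CC2)c([C@@H](C)c2ccccc2)o1` differs from compound 1 by hydrogen in place of chloro on an aromatic carbon. For the measured compounds named here, compound 2 already carries a plain phenyl on a different core and gives 0.9 L/kg, the same value as compound 1, which offers the only guide here. The step of a 1.1-fold lower number from compound 1 to compound 3 (0.05 log units; within the scatter) is expected to be small, at most a slight fall, and to stay within the scatter. Compound 3 is therefore estimated at about 0.8 L/kg in this assay, in a range from 0.5 L/kg to 1.3 L/kg.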

Compound 3, volume of distribution at steady state: 0.8 L/kg
Beside the measured number, compound 3's estimate shows no gap at the digits printed; measured number inside the range.
By their numbers in this assay, from the lowest: compounds 3, 1 and 2 (each within the scatter of the next).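

Compounds 1 and 2 differ in more than one place, so they could not isolate a single change. Compound 3 gives the first such reading: replacing 3-chlorophenyl with phenyl, on the shared core, is a 1.1-fold lower number from compound 1 to compound 3 (0.05 log units; within the scatter) in this assay and so cannot be told apart from no effect. At this aromatic carbon, meta to a large group, chloro and hydrogen therefore give matching readings of how far the compound spreads outside the plasma, and no measurement available explains this result.

Still open, going by these compounds, is whether a different group at this place, such as an amine or a carboxylic acid, would give a step beyond the scatter. Also open, on these data alone, is whether chloro in place of hydrogen on the phenyl of compound 2 would give a similar result on that other core.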